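The compounds below may be only part of what the source reports. "The series", "measured", "known", "first", "only" and "open" are said of these compounds alone.

All three measured compounds were tested in an assay on HEK293 cells for inhibition of acid ceramidase (Homo sapiens), read by fluorescence, with stated times of 30 min and 1 h; on this read-out lower numbers stand for stronger inhibition and higher numbers for weaker inhibition:

Compound 1, `Cc1ccccc1CNC(=O)n1cnc2ccccc21`, gives 55.9 nM.
Compound 2, `O=C(NCCCCc1ccccc1)n1cnc2ccccc21`, gives 2.5 nM.
Compound 3, `Cc1ccccc1CNC(=O)n1c(N)nc2ccccc21`, gives 68.4 nM.

Compound 2 has the lowest number of the three; the difference between its core and the core of compound 1 is not broken down here. Compound 3 differs from compound 1 by one change, (amino in place of hydrogen on an aromatic carbon), and that change produced a 1.2-fold higher number from compound 1 to compound 3 (0.09 log units; within the scatter).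

Compound 4, `Nc1nc2ccccc2n1C(=O)NCCCCc1ccccc1`, has not been measured. It differs from compound 2 by amino in place of hydrogen on an aromatic carbon, the same change in the same place. Because the step of a 1.2-fold higher number from compound 1 to compound 3 (0.09 log units; within the scatter) stayed within the scatter, the corresponding step from compound 2 is expected to be small too, a 1.2-fold higher number from compound 2 to compound 4 (0.08 log units; within the scatter). Compound 4 is therefore estimated at 3 nM, expected to fall between 1.5 nM and 6.5 nM.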

Compound 4, half-maximal inhibitory concentration: 0.9 nM
Estimate against measurement, compound 4: 3.3-fold (0.52 log units) above; the measured number lies below the stated range.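

Putting amino in place of hydrogen on the aromatic carbon gave a 2.8-fold lower number from compound 2 to compound 4 (0.44 log units; beyond the scatter), so the change did not behave here as it did on the core of compound 1. Set side by side, the two steps differ: the same change on two cores in this assay, a 1.2-fold higher number (0.09 log units; within the scatter) from compound 1 to compound 3 and a 2.8-fold lower number (0.44 log units; beyond the scatter) from compound 2 to compound 4, 3.4-fold (0.53 log units) apart, beyond the scatter of two such steps The effect of this change therefore cannot be carried unaltered from one core to another in this series, although two pairs of compounds do not show why the steps differ or what the change would do on any further core.

Still open, going by these compounds, is whether a methyl or hydroxyl group on that same aromatic carbon would give a step like either of these. On these data alone, it is also open how amino would behave on a compound with a longer chain than compound 4.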